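Moving the Hydroxymethyl Group Around the Phenyl Ring

This account rests on a few compounds, and the source may have more. Where it says the series, first, only, none or still open, it means among the compounds named here.

Compound 1, `CCCC[S+]([O-])c1sc2nc(-c3nccs3)cc(-c3cccc(CO)c3)c2c1N`, was tested in an assay for inhibition of 15-hydroxyprostaglandin dehydrogenase [NAD(+)] (Homo sapiens), read by fluorescence, with a stated time of 15 min, in the presence of a further agent that is not named here (a higher number here means a weaker inhibitor, a lower number a stronger inhibitor), where compound 1 gives 4.3 nM. Two companions were measured the same way: compound 2, `CCC[S+]([O-])c1sc2nc(-c3cccs3)cc(C(=O)N(C)C)c2c1N`, gives 14.7 nM, and compound 3, `CCCC[S+]([O-])c1sc2nc(-c3nccn3C)nc(-c3ccccc3)c2c1N`, gives 3.7 nM. Among these three numbers compound 1 stands second highest. Its nearest neighbour is compound 3, whose value lies within the usual scatter, so no order between those two can be claimed; compound 2 sits beyond the scatter with the higher number.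

Compound 4, `CCCC[S+]([O-])c1sc2nc(-c3nccs3)cc(-c3ccc(CO)cc3)c2c1N`, has not yet been measured. It differs from compound 1 in one place: 4-(hydroxymethyl)phenyl in place of 3-(hydroxymethyl)phenyl on an aromatic carbon. The two have the same atoms, joined differently. The substituted phenyl ring sits on an aromatic carbon of the core of compound 1, ortho to a fused ring, meta to a 1,3-thiazol-2-yl group and opposite the ring nitrogen.

For the measured compounds named here, no measured pair in this set shows such a change, so the step has no direct precedent here. The author expects a small step, a 1.4-fold higher number from compound 1 to compound 4 (0.14 log units; within the scatter), likely not beyond the scatter in this assay, in either direction. Compound 4 is accordingly estimated at 6 nM, with a range from 2 nM to 18 nM.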

Compound 4, half-maximal inhibitory concentration: 2.5 nM
Compound 4: the middle estimate sits 2.4-fold (0.38 log units) above what was measured; the range from low to high includes it.
By their numbers in this assay, from the lowest: compounds 4, 3 and 1 (each within the scatter of the next); then compound 2.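

In this assay, moving the hydroxymethyl group from 3-(hydroxymethyl)phenyl to 4-(hydroxymethyl)phenyl gives a 1.7-fold lower number from compound 1 to compound 4 (0.24 log units; within the scatter), so the two compounds cannot be ranked. For the compounds shown here, this pair is the first in the set to differ in one place, and it gives the first direct reading at this aromatic carbon: with the same atoms joined differently, compound 4 at 2.5 nM and compound 1 at 4.3 nM cannot be told apart in this assay. Nothing available explains this result or shows how either compound behaves beyond this single read-out.

As far as these compounds go, what a carboxylic acid or an aminomethyl group would do in place of the hydroxymethyl group on the phenyl ring remains open, as does the effect of a longer chain such as hydroxyethyl. From the compounds shown here alone, it is also open whether the same swap would read the same way with a group other than the 1,3-thiazol-2-yl group on the core, as the step is known only from the core of compound 1.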